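The compounds below may be only part of what the source reports. "The series", "measured", "known", "first", "only" and "open" are said of these compounds alone.

Going by the values given here, in a functional assay on HeLa cells (Homo sapiens) for cytotoxicity, read by MTT assay (on this read-out lower numbers stand for stronger inhibition and higher numbers for weaker inhibition), compound 1 (`CCCC(O)CC(=O)O[C@H](CC=C(C)C)C1=CC(=O)c2c(O)ccc(O)c2C1=O`) gives 59300 nM and compound 2 (`CCC(C)(O)CC(=O)O[C@H](CC=C(C)C)C1=CC(=O)c2c(O)ccc(O)c2C1=O`) gives 25200 nM, the lower of the two numbers so far. The next compound, compound 3 (`CCC(CO[C@H](CC=C(C)C)C1=CC(=O)c2c(O)ccc(O)c2C1=O)OC`), departs from compound 2 by 2-methoxybutyl in place of (2-hydroxy-2-methylbutyl)carbonyl on an oxygen on a saturated carbon. In words, 2-methoxybutyl stands in place of (2-hydroxy-2-methylbutyl)carbonyl on an oxygen on a saturated carbon. Among the compounds with values here, only one measured step bears on this change: a 2.4-fold lower number from compound 1 to compound 2 (0.37 log units; beyond the scatter). That step is modest and altered only the chain, with the carbonyl retained in both compounds, so it is a weak guide to a change that removes the carbonyl. Within the data shown here, with no measured compound lacking that carbonyl, no step clearly beyond the scatter can be expected in this assay, in either direction. The expected change is a 1.3-fold lower number from compound 2 to compound 3 (0.10 log units; within the scatter). For compound 3 the estimated value is 20000 nM, with an expected range from 6000 nM to 65000 nM.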

Compound 3, half-maximal inhibitory concentration: 63500 nM
The estimate for compound 3 lay 3.2-fold (0.50 log units) below the measured number; low and high end bracket the measured number.
By their numbers in this assay, from the lowest: compound 2; then compounds 1 and 3 (each within the scatter of the next).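

In this assay the move from an ester side chain to one without the carbonyl shows a 2.5-fold higher number from compound 2 to compound 3 (0.40 log units; beyond the scatter) and so gives up the edge that compound 2 held. Measured against the other ester, the same kind of replacement shows a 1.1-fold higher number from compound 1 to compound 3 (0.03 log units; within the scatter) and leaves compound 3 level with compound 1, so at this oxygen on a saturated carbon, 2-methoxybutyl matches (2-hydroxypentyl)carbonyl, but not (2-hydroxy-2-methylbutyl)carbonyl. No supporting evidence is available to explain this result.

The change to compound 3 alters the carbonyl, the hydroxyl and the chain together, which leaves open which of these accounts for the step. Going by these compounds, how a 2-hydroxy-2-methylbutyl chain held on this oxygen without the carbonyl, or a chain ending in an amine or a carboxylic acid, would read here also remains open.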